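The source may hold more compounds than are shown below. What is called first, only, known or untested is meant among the compounds shown, and "the series" means these compounds.

Measured compounds:
Compound 1, `CN(C)c1ccc2c(=O)c(C(=O)Nc3cc(F)cc(F)c3)cn(-c3ccc(Cl)c(OCCCCCCC[N+]4(C)CCCCC4)c3)c2n1`, gives 90.5% in an assay on LX2 cells for inhibition of COL1A1 promoter (Homo sapiens), read by a luciferase reporter, with a stated time of 24 h, tested at 50 uM; a higher number here means a stronger effect of the compound at the concentration tested, a lower number a weaker effect.
Compound 2, `CC[N+]1(CCCCCCCOc2cc(-n3cc(C(=O)Nc4cc(F)cc(F)c4)c(=O)c4ccc(N(C)C)nc43)ccc2Cl)CCCCC1`, gives "not active" (no number reported) in this assay.
Compound 3, `Cc1ccc(-n2cc(C(=O)Nc3cc(F)cc(F)c3)c(=O)c3ccc(N(C)C)nc32)cc1OCCCCCCC[N+]1(C)CCN(C)CC1`, gives 25% in this assay.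

Of the two compounds with a reported number, compound 3 stands lowest; compound 1 lies above it by a margin well beyond the usual scatter, while compound 2 is reported only as not active, with no number given. Compound 4, `CN1CC[N+](C)(CCCCCCCOc2cc(-n3cc(C(=O)Nc4cc(F)cc(F)c4)c(=O)c4ccc(N(C)C)nc43)ccc2Cl)CC1`, has not yet been measured. It differs from compound 3 in a single place: chloro in place of methyl on an aromatic carbon. For the measured compounds named here, no two measured compounds differ from each other in only one place, so no measured step tells directly what this exchange does. Compound 1 carries the same chloro that enters in compound 4 and gives a far higher number than compound 3, but compound 1 also differs in its charged ring, so that comparison is only partial. A moderate upward step is expected, a number 20 percentage points higher from compound 3 to compound 4 (beyond the scatter), though it could also stay within the scatter. Compound 4 is estimated at 45%, with a range from 15% to 80%.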

Compound 4, a percentage reported as inhibition, at one concentration (the size of the read-out at that concentration, not a potency): 45.2%
Compound 4: middle estimate off by 0.2 percentage points, on the low side, within the range that was stated.
By their numbers in this assay, from the lowest: compound 3; then compound 4; then compound 1.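

In this assay, chloro in place of methyl on this aromatic carbon, ortho to a large group and para to a large group, gives a number 20.2 percentage points higher from compound 3 to compound 4 (beyond the scatter), so with the ring at the chain end held constant, the exchange raises the read-out. With the chloro held constant, the group of 8 heavy atoms in place of the group of 7 heavy atoms on the saturated chain carbon gives a number 45.3 percentage points lower from compound 1 to compound 4 (beyond the scatter), a large step against the modest one at the aromatic carbon. Nothing measured here explains either step.

On these data alone, whether the chloro step carries over to compounds with the ring of compound 1 at the chain end remains open. So does the outcome of a bromo or methoxy on the same aromatic carbon, or of a morpholine ring at the chain end.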